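The compounds below may be only part of what the source reports. "The series", "measured", "known", "first", "only" and "open" are said of these compounds alone.

Working notes on the series in an ADME assay on HEL cells (Homo sapiens) for cytotoxicity, with a stated time of 3 days; a lower number here means that less compound is tolerated, a higher number that more compound is tolerated. Compound 3 `Cc1cc(-c2ccoc2)c2ncc(CSCCc3ccccc3)n2c1` sits highest among the two numbers shown, giving 100 ug/mL in this assay. Compound 2 `Cc1cc(-c2ccsc2)cn2c(CSCc3ccccc3)cnc12` gives 4 ug/mL in this assay, a gap beyond the scatter. Compound 1 `Cc1cc(-c2ccc3[nH]ccc3c2)cn2c(CSCCc3ccccc3)cnc12` reaches only a limit of this assay, >= 20 ug/mL, so it yields no number; this is the limit of >= 20 ug/mL in this assay, at which 1 of the 3 values shown sits. Compound 4 `Cc1cc(-n2ccnc2)c2ncc(CSCCc3ccccc3)n2c1` is not yet measured. It differs from compound 3 by 1H-imidazol-1-yl in place of furan-3-yl on an aromatic carbon on the aromatic carbon ortho to a fused ring and meta to the methyl group. For the measured compounds named here, no measured step between these compounds exists, so any expectation rests on compound 3 alone. The step from compound 3 to compound 4 is expected to be small, of size a 2.0-fold lower number from compound 3 to compound 4 (0.30 log units; within the scatter), downward if anything. Compound 4 is therefore estimated at 50 ug/mL, within 10 ug/mL to 100 ug/mL.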

Compound 4, minimum cytotoxic concentration: 20 ug/mL
Beside the measured number, compound 4's estimate is 2.5-fold (0.40 log units) above it; low and high end bracket the measured number.
By their numbers in this assay, from the lowest: compound 2; then compound 4; then compound 3.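

For the compounds shown here, replacing furan-3-yl with 1H-imidazol-1-yl gives a 5.0-fold lower number from compound 3 to compound 4 (0.70 log units; beyond the scatter) in this assay, the only step available at this position. The aromatic carbon ortho to a fused ring is therefore not indifferent to which five-membered aromatic ring it carries, and the imidazolyl compound is tolerated at a lower concentration. Nothing measured in the series accounts for this change.

On these data alone, how an amine or a carboxylic acid on this carbon would read remains open. So does whether the same exchange gives a step of similar size with a longer chain on the sulfur.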